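The compounds below may be only part of what the source reports. "The series", "measured", "known", "first", "only" and "open" are said of these compounds alone.

Going by the values given here, in a functional assay on MOLT-4 cells (Homo sapiens) (a higher number here means a weaker inhibitor, a lower number a stronger inhibitor), compound 2 (`COc1cc(NC(C)CCCNC(=O)NOCc2ccccc2)c2ncccc2c1`) gives 12000 nM, the only actual number so far. Compound 1 (`COc1cc(NC(C)CCCNC(=O)NCCCO)c2ncccc2c1`) reaches only a limit of the assay, > 100000 nM. Compound 3 (`COc1cc(NC(C)CCCNC(=O)NC(CO)(CO)CO)c2ncccc2c1`) keeps the shared core and the urea-bearing chain of compound 2 but has 2-hydroxy-1,1-bis(hydroxymethyl)ethyl in place of benzyloxy on an amide-type nitrogen. Among the compounds with values here, one measured step bears on this change. With benzyloxy in place of 3-hydroxypropyl at that same place, the result is an at least 8.3-fold lower number from compound 1 to compound 2 (0.92 log units; beyond the scatter). Compound 3 gives up the benzyloxy and, like compound 1, carries a hydroxy-bearing alkyl group there, so a step of similar size in the opposite direction is expected in this assay, possibly ending at the limit. The estimated change is a 5.8-fold higher number from compound 2 to compound 3 (0.77 log units; beyond the scatter). For compound 3 the expected value is 70000 nM, with an estimated range of 20000 nM to 100000 nM.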

Compound 3, half-maximal inhibitory concentration: > 100000 nM
Compound 3 was reported as a limit; the forecaster's own chance of this, stated with the estimate: 55%; at least 1.4-fold (0.15 log units) between middle value and limit.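

Putting 2-hydroxy-1,1-bis(hydroxymethyl)ethyl in place of benzyloxy on the amide-type nitrogen gives an at least 8.3-fold higher number from compound 2 to compound 3 (0.92 log units; beyond the scatter) in this assay, so this change, like the one linking compound 1 and compound 2, leaves benzyloxy as the only group shown here with a value short of the limit. Compound 3 gives > 100000 nM, which is a limit of the assay and not a number. The step between compound 1 and compound 3 cannot be read, so the two hydroxy-bearing alkyl groups cannot be ranked: the limit of > 100000 nM in this assay, at which 2 of the 3 values shown sit.

From the compounds shown here alone, it remains open whether the aromatic ring of benzyloxy or its oxygen on the amide-type nitrogen matters more, which a benzyl or a methoxy group at this place would help to separate. Going by these compounds, how an amine or a carboxylic acid at the end of a longer chain would fare there also remains open.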